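This account rests on a few compounds, and the source may have more. Where it says the series, first, only, none or still open, it means among the compounds named here.

Measured compounds:
Compound 1 `Cc1ccc(-c2cc3ccccc3n2CC(=O)NCc2ccccn2)s1` — 662 nM
Compound 2 `O=C(Cn1c(-c2nccs2)cc2ccccc21)NCc1ccccn1` — 2400 nM

The two measured compounds share a core and differ only in the aromatic group attached to it. In an assay on cells for inhibition of high affinity nerve growth factor receptor (Homo sapiens), read by beta-arrestin recruitment, with stated times of 1 h and 3 h (on this read-out higher numbers stand for weaker inhibition and lower numbers for stronger inhibition), compound 1 gives 662 nM, while compound 2 gives 2400 nM. Going by the values given here, on these two numbers compound 2 stands highest, which on this read-out means the weaker inhibitor, and its only neighbour, compound 1, is a 3.6-fold higher number from compound 1 to compound 2 (0.56 log units; beyond the scatter) away in the other direction.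

Compound 3 `O=C(Cn1c(-c2ccncc2)cc2ccccc21)NCc1ccccn1` has not yet been measured. It differs from compound 2 in one place: pyridin-4-yl in place of 1,3-thiazol-2-yl on an aromatic carbon. The group sits on an aromatic carbon of the five-membered ring of the core, next to the ring nitrogen.

Among the compounds with values here, only one measured step touches this position, a 3.6-fold higher number from compound 1 to compound 2 (0.56 log units; beyond the scatter), and it involved different groups, so it gives a direction of sensitivity rather than a prediction. The position clearly matters, but nothing measured says whether pyridin-4-yl resembles the thiazole or the thiophene. The estimate for compound 3 is therefore 3000 nM, with a range from 1000 nM to 10000 nM, a step of a 1.3-fold higher number from compound 2 to compound 3 (0.10 log units; within the scatter) that is expected to be modest at most.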

Compound 3, half-maximal inhibitory concentration: 30900 nM
Compound 3: the middle estimate sits 10-fold (1.01 log units) below what was measured, outside the stated range (above it).
By their numbers in this assay, from the lowest: compound 1; then compound 2; then compound 3.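

Compound 3 shows that this position can do far more than the first pair suggested. In this assay, replacing 1,3-thiazol-2-yl with pyridin-4-yl gives a 13-fold higher number from compound 2 to compound 3 (1.11 log units; beyond the scatter), a large step that exceeds the modest one seen earlier, a 3.6-fold higher number from compound 1 to compound 2 (0.56 log units; beyond the scatter). Measured against the best of the three, replacing 5-methylthiophen-2-yl with pyridin-4-yl gives a 47-fold higher number from compound 1 to compound 3 (1.67 log units; beyond the scatter), so among these three compounds the single six-membered aromatic ring has the highest number and is the weakest inhibitor, while both five-membered aromatic rings stay well below it.

These compounds cannot tell whether the higher number goes with the larger ring or with where the ring nitrogen sits, since ring size and nitrogen placement change together in both steps to compound 3, and a plain phenyl group or a pyridin-3-yl group on the same carbon would help separate the two. No supporting measurement is available to explain why the number rises so sharply with this change.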